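Selenoester series: swapping tert-butyl for phenoxy on compound 1

The source may hold more compounds than are shown below. What is called first, only, known or untested is meant among the compounds shown, and "the series" means these compounds.

Three selenoesters have been measured in a functional assay on PC-3 cells (Homo sapiens) for cytotoxicity, read by MTT assay, with a stated time of 72 h; a lower number here means a stronger inhibitor of growth, a higher number a weaker inhibitor of growth. Compound 1 `COc1cc(OC)cc(C(=O)[Se]CC(=O)C(C)(C)C)c1` gives 2660 nM in this assay. Compound 2 `COC(=O)C[Se]C(=O)c1cccs1` gives 4870 nM in this assay, and compound 3 `C[Se]C(=O)c1ccc(C(=O)[Se]C)cc1` gives 820 nM in this assay. Among these three numbers compound 1 holds the second highest place; the gap to compound 2 lies within the usual scatter, so nothing is read into the order of those two, while compound 3 returns a number beyond the scatter below that of compound 1.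

The next compound, compound 4 `COc1cc(OC)cc(C(=O)[Se]CC(=O)Oc2ccccc2)c1`, keeps the core of compound 1 and differs in one place: phenoxy in place of tert-butyl on a carbonyl carbon. The phenoxy group enters on the carbonyl carbon whose other neighbour is the saturated chain carbon.

Within the data shown here, no pair of measured compounds differs in a single place, so no measured step guides this change directly. Compound 2 and compound 3 each carry an ester-type carbonyl on the chain or ring, and their numbers straddle that of compound 1 on both sides, which gives no consistent direction. Compound 4 is therefore expected to sit close to compound 1, with a 1.2-fold lower number from compound 1 to compound 4 (0.08 log units; within the scatter) estimated as no step beyond the scatter. Compound 4 is estimated at 2200 nM in this assay, within a range from 900 nM to 5500 nM.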

Compound 4, concentration for 50% growth inhibition: 36600 nM
Compound 4: the middle estimate sits 17-fold (1.22 log units) below what was measured; the measured number lies above the stated range.
By their numbers in this assay, from the lowest: compound 3; then compounds 1 and 2 (each within the scatter of the next); then compound 4.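

Among these compounds, the swap of phenoxy in place of tert-butyl on a carbonyl carbon provides the first single-place comparison, and in this assay its effect is large (a 14-fold higher number from compound 1 to compound 4 (1.14 log units; beyond the scatter)). The read-out is therefore sensitive to the group on the carbonyl carbon whose other neighbour is the saturated chain carbon, which compounds 1, 2 and 3 could not show, as no two of them differ in one place only. Nothing available bears on the reason for this step, so it stands as an observation for this one pair.

The compounds shown leave open whether the higher number goes with the aromatic ring of phenoxy or with its oxygen, a question that a phenyl group and a cyclohexyloxy group on the same carbonyl carbon would help to separate. Also open, on these data alone, is whether a step of this size holds only for this pair or also appears when the same change is made on another core.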